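The compounds below may be only part of what the source reports. "The series", "measured", "known", "first", "only" and "open" are said of these compounds alone.

Working notes on the series. In a functional assay on the whole organism with Canis familiaris (Canis lupus familiaris) as the target, at a dose of 5 mg/kg by the intravenous route (a higher number here means a stronger effect of the compound at the dose given, a lower number a weaker effect), compound 3 `Cc1nc2c(OCc3ccccc3)cccn2c1CN` gives 49%, the highest of the three numbers recorded so far. Compound 2 `Cc1nc2c(COc3ccccc3)cccn2c1N` gives 34% in this assay, and compound 1 `Cc1nc2c(OCc3ccccn3)cccn2c1N` gives 24%; both gaps to compound 3 lie beyond the scatter, so compound 3 stands clearly on top.

The untested compound 4 `COc1c(C)nc2c(OCc3ccccc3)cccn12` differs from compound 3 in one place: methoxy in place of aminomethyl on an aromatic carbon. Among the measured compounds shown here, no tested pair carries this change, so its size is open. For the measured compounds named here, a moderate drop in this assay is expected, a number 19 percentage points lower from compound 3 to compound 4 (beyond the scatter), rather than a change within the scatter, since compound 3 with the aminomethyl group is the only member above the others. Compound 4 is estimated at 30%, with a range from 10% to 55%.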

Compound 4, a percentage reported as inhibition, in the whole organism at one dose (the size of the read-out at that dose, not a potency): 37%
For compound 4 the middle estimate is 7 percentage points below the measured one; measured number inside the range.
By their numbers in this assay, from the lowest: compounds 1, 2 and 4 (each within the scatter of the next, the first and the last beyond it); then compound 3.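

In this assay, the exchange of aminomethyl for methoxy on this aromatic carbon costs a modest but real part of the effect, a number 12 percentage points lower from compound 3 to compound 4 (beyond the scatter). Compound 4 has no hydrogen-bond donor in this group yet retains a clear effect at this dose, so a donor here is not essential for a response. No available data explain the size of this step.

Still open, from the compounds shown here alone, is how a hydroxymethyl group or a longer aminoethyl chain would fare at this position on the core of compound 3. Going by these compounds, with a single dose, potency also remains unknown.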